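The source may hold more compounds than are shown below. What is called first, only, known or untested is meant among the compounds shown, and "the series" means these compounds.

Measured so far:
- compound 1 `COC(=O)C1=C(C)NC(=O)NC1c1ccccc1` — "not active" (no number reported)
- compound 2 `COC(=O)C1=C(C)NC(=O)NC1c1ccc(OC)cc1` — 59200 nM

In an assay for inhibition of beta-glucuronidase (Bos taurus), read by spectrophotometry, with a stated time of 30 min (on this read-out higher numbers stand for weaker inhibition and lower numbers for stronger inhibition), compound 1 is recorded as "not active" (no number reported), with no number attached, so it stands only as the weak end of the pair. In this assay compound 2 gives 59200 nM, a weak but countable inhibition. Compound 3 `COC(=O)C1=C(C)NC(=O)NC1c1ccccc1OC` is not yet measured; it differs from compound 1 by methoxy in place of hydrogen on an aromatic carbon. Within the data shown here, with no step between measured compounds to lean on, the change is expected to move this assay little, at most a modest gain over compound 1 and quite possibly none beyond the scatter. For compound 3 the estimate is 90000 nM, within 30000 nM to 300000 nM, with a real chance that only a limit is reported.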

Compound 3, half-maximal inhibitory concentration: 59200 nM
Beside the measured number, compound 3's estimate is 1.5-fold (0.18 log units) above it; measured number inside the range.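

No step can be read from compound 1 to compound 3: compound 1 is recorded as "not active" (no number reported). The compounds shown leave open how far methoxy in place of hydrogen shifts inhibition. Nothing available bears on the result.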